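From 3-nitrophenyl to 4-cyanophenyl: cytotoxicity working notes

The compounds below may be only part of what the source reports. "The series", "measured", "known", "first", "only" and "open" are said of these compounds alone.

Compound 1 `CC1=C(C(=O)OC2CCCCC2)C(c2cccc(O)c2)NC(=O)N1` gives > 10000 nM as a limit
Compound 2 `CC1=C(C(=O)OCC2CCCCC2)C(c2cccc(O)c2)NC(=O)N1C` gives > 10000 nM as a limit
Compound 3 `CCC1=C(C(=O)OCC2CCCCC2)C(c2cccc([N+](=O)[O-])c2)NC(=O)N1` gives > 10000 nM as a limit

All three read-outs come from an ADME assay on CEMx174 cells (Homo sapiens) for cytotoxicity (on this read-out higher numbers stand for lower toxicity in this test and lower numbers for higher toxicity in this test), and none of them is a number. Compound 3 stands at a limit of the assay (> 10000 nM). Within the data shown here, the picture across the series is the limit of > 10000 nM in this assay, at which 3 of the 3 values shown sit, and no two measured compounds differ in only one place.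

Compound 4 `CCC1=C(C(=O)OCC2CCCCC2)C(c2ccc(C#N)cc2)NC(=O)N1` has not yet been measured in this assay and carries 4-cyanophenyl in place of 3-nitrophenyl on a saturated ring carbon and the rest of compound 3 stays unchanged.

Among the measured compounds shown here, with no measured single-place step to draw on, the size of this change cannot be read from the series. No step beyond the scatter is expected. This expectation rests on compound 3, whose read-out is the limit > 10000 nM and so gives no number to start from. The estimated change is a step that the limit leaves unreadable from compound 3 to compound 4 and this expected step stays within the scatter. For compound 4 the estimate is 12000 nM with an expected range of 6000 nM to 30000 nM and the read-out may again be only a limit.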

Compound 4, half-maximal cytotoxic concentration: > 10000 nM
Compound 4: no number, only a limit; the forecaster's own chance of this, stated with the estimate: 85%; the middle value does not contradict the limit.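

In this assay compound 4 gives > 10000 nM, which is a limit and not a number. Among these compounds, compound 3 also stands at a limit, and no step from compound 3 to compound 4 can be read. The compounds shown leave open at what concentration, if any, each becomes cytotoxic, and whether 4-cyanophenyl and 3-nitrophenyl differ there.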